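Fluoro to Methoxy Swap on Two Related Cores

The compounds below may be only part of what the source reports. "The series", "measured", "known", "first", "only" and "open" are said of these compounds alone.

Compound 1 `COC(=O)[C@@]1(C)CCC=C2[C@@H]1CC[C@@H](C)[C@]2(C)Cc1c[nH]c2ccc(F)cc12` and compound 2 `COC(=O)[C@@]1(C)CCC=C2[C@@H]1CC[C@@H](C)[C@]2(C)Cc1c[nH]c2ccc(OC)cc12` share one core; compound 3 `COC(=O)[C@@]1(C)CC[C@@H]2C3=C1CC[C@@H](C)[C@]3(C)C[C@@H]1c3cc(F)ccc3N[C@H]21` has the same atoms joined differently, and the difference between the two cores is not broken down here. In a functional assay on A549 cells (Homo sapiens) for inhibition, read by sulforhodamine B assay, with a stated time of 48 h (on this read-out higher numbers stand for weaker inhibition of growth and lower numbers for stronger inhibition of growth), compound 1 gives 6200 nM, compound 2 gives 2200 nM and compound 3 gives 25000 nM. The change methoxy in place of fluoro on an aromatic carbon produced a 2.8-fold lower number from compound 1 to compound 2 (0.45 log units; beyond the scatter). Compound 4 `COC(=O)[C@@]1(C)CC[C@@H]2C3=C1CC[C@@H](C)[C@]3(C)C[C@@H]1c3cc(OC)ccc3N[C@H]21` carries the same kind of change on the core of compound 3, (methoxy in place of fluoro on an aromatic carbon); here the aromatic carbon belongs to a fused or bridged system of five rings rather than two. For compound 4 in this assay the step of a 2.8-fold lower number from compound 3 to compound 4 (0.44 log units; beyond the scatter) is expected, resting on the step of a 2.8-fold lower number from compound 1 to compound 2 (0.45 log units; beyond the scatter) seen on the other core. Going by the values given here, compound 4 is therefore estimated at 9000 nM, with a range of 4000 nM to 22000 nM that reflects the single measured instance of this change.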

Compound 4, concentration for 50% growth inhibition: 22000 nM
The estimate for compound 4 lay 2.4-fold (0.39 log units) below the measured number; low and high end bracket the measured number.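

In this assay methoxy in place of fluoro on an aromatic carbon gave a 1.1-fold lower number from compound 3 to compound 4 (0.06 log units; within the scatter) on the five-ring system, so no effect of the change can be claimed on that core. The two steps, one beyond the scatter and one within it, cannot be told apart: the same change on two cores in this assay, a 2.8-fold lower number (0.45 log units; beyond the scatter) from compound 1 to compound 2 and a 1.1-fold lower number (0.06 log units; within the scatter) from compound 3 to compound 4, 2.5-fold (0.39 log units) apart, within the scatter of two such steps. Going by these compounds alone, this agrees with the change carrying over between the cores, but with only two steps it does not show that it carries over, nor does it show that the cores respond differently.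

Only fluoro and methoxy appear at this aromatic carbon. From the compounds shown here alone, how an amine, a carboxylic acid or a longer chain there would read on either core stays open.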